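Enantiomer of compound 3 in the antiproliferative assay

This account rests on a few compounds, and the source may have more. Where it says the series, first, only, none or still open, it means among the compounds named here.

Measured so far:
compound 1 `CC1(C)[C@@H]2CC3=N[C@@H](CCC(=O)O)C(=O)O[C@@]3(C)[C@H]1C2` gives > 1200000 nM.
compound 2 `C[C@@H]1N=C2C[C@@H]3C[C@@H](C3(C)C)[C@]2(C)OC1=O` gives > 2000000 nM.
compound 3 `CC1(C)[C@H]2CC3=NCC(=O)O[C@]3(C)[C@@H]1C2` gives > 2000000 nM.

For the measured compounds named here, in an ADME assay on MCF-10A cells (Homo sapiens) for antiproliferative activity, read by sulforhodamine B assay, with a stated time of 48 h (a lower number here means a stronger inhibitor, a higher number a weaker inhibitor), every value so far is a limit, not a number. Compound 3 sits at the limit of > 2000000 nM in this assay, at which 2 of the 3 values shown sit. Compound 1 sits at the limit of > 1200000 nM in this assay, at which 1 of the 3 values shown sits. Going by the values given here, the one comparable pair, a step that the two limits leave unreadable from compound 1 to compound 2, is a step that cannot be read. Compound 4 `CC1(C)[C@@H]2CC3=NCC(=O)O[C@@]3(C)[C@H]1C2` differs from compound 3 by the two compounds have the same atoms and bonds and differ only in configuration as drawn: 3 of 3 stereo elements differ (all stereocentres are inverted: mirror images); a stereocentre at a saturated ring carbon is drawn R in compound 3 and S in compound 4; a stereocentre at a saturated ring carbon is drawn R in compound 3 and S in compound 4; a stereocentre at a saturated ring carbon is drawn R in compound 3 and S in compound 4. Among the compounds with values here, no measured step involves a change of configuration alone, so nothing here sizes such a step; the only measured step is unreadable. Compound 4 is therefore expected to behave like compound 3 and to reach the limit again, an expected step of a number no higher from compound 3 to compound 4 (the limit leaves the size open). Compound 4 is estimated at 2000000 nM, in the range 800000 nM to 5000000 nM.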

Compound 4, half-maximal inhibitory concentration: > 900000 nM
Compound 4: no number, only a limit (the forecaster's own chance of this, stated with the estimate: 90%); the middle value is on the limit's open side.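

In this assay compound 4 gives > 900000 nM, a limit and not a number. For the compounds shown here, no step from compound 1, compound 2 or compound 3 to compound 4 can be read. From the compounds shown here alone, whether inverting all stereocentres, as between compound 3 and compound 4, changes the value in this assay stays open.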